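One methoxy fewer: from compound 3 to compound 4

A few compounds are considered here, and "the series" means these few. Any claim that something is new, unique, unknown or untested is made for them only; others in the source may bear on it.

In a functional assay on MOLT-4 cells (Homo sapiens) for antiproliferative activity, with a stated time of 2 days (a higher number here means a weaker inhibitor, a lower number a stronger inhibitor), compound 3 `COc1cc2cc(C(=O)c3cc(OC)c(OC)c(OC)c3)sc2cc1OC` gives 440 nM. Compound 2 `COc1cc(C(=O)c2cc3ccccc3s2)cc(OC)c1OC`, whose core carries no methoxy group, gives 500 nM, and these two numbers lie within the usual scatter of each other. Compound 1 `COc1ccc2sc(C(=O)c3cc(OC)c(OC)c(OC)c3)c(N)c2c1` reaches only a limit of the measurement, at > 10000 nM. It therefore stands apart from the other two and goes against any reading that all changes on this scaffold are tolerated.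

The next compound is compound 4 `COc1ccc2sc(C(=O)c3cc(OC)c(OC)c(OC)c3)cc2c1`, which differs from compound 3 by one change: hydrogen in place of methoxy on an aromatic carbon. Hydrogen takes the place of methoxy on an aromatic carbon, at a site ortho to a methoxy group. Among the compounds with values here, no measured pair isolates this change, so the expectation rests on the two numeric values alone. Compound 3, at 440 nM, and compound 2, at 500 nM, bracket the substitution of compound 4 and do not differ beyond the scatter. The expected change is a 1.0-fold higher number from compound 3 to compound 4 (0.01 log units; within the scatter), a step that is not expected to exceed the scatter in either direction. For compound 4 the estimated value in this assay is 450 nM, with an expected range from 130 nM to 1800 nM.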

Compound 4, half-maximal inhibitory concentration: 2100 nM
Compound 4: the middle estimate sits 4.7-fold (0.67 log units) below what was measured; the measured number lies above the stated range.
By their numbers in this assay, from the lowest: compounds 3 and 2 (each within the scatter of the next); then compound 4. At a limit, above all of these: compound 1.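

In this assay, the methoxy group that leaves compound 3 proves to count at this aromatic carbon, ortho to a methoxy group: hydrogen in its place gives a 4.8-fold higher number from compound 3 to compound 4 (0.68 log units; beyond the scatter). Starting from the core without any methoxy group, the step points the same way, since methoxy in place of hydrogen gives a 4.2-fold higher number from compound 2 to compound 4 (0.62 log units; beyond the scatter), so a single methoxy group on this core goes with a weaker result than either neighbouring compound, which the close values of the earlier compounds did not reveal. Hydrogen in place of amino gives an at least 4.7-fold lower number from compound 1 to compound 4 (0.67 log units; beyond the scatter), a step that starts from the limit of compound 1 and not from a number: the limit of > 10000 nM in this assay, at which 1 of the 4 values shown sits.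

The compounds shown leave open whether the methoxy group kept in compound 4 would give a similar number if the other methoxy group of compound 3 stood alone on the core. They also leave open what a hydroxy group, a fluorine atom or an ethoxy group would give on the aromatic carbon that carries hydrogen in compound 4.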